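A few compounds are considered here, and "the series" means these few. Any claim that something is new, unique, unknown or untested is made for them only; others in the source may bear on it.

Compound 2 `CN(CCNCc1cn(Cc2ccc(Br)cc2)nn1)CCNc1ccnc2cc(Cl)ccc12` gives the lowest of the two numbers measured in a functional assay on NCI-H460 cells (Homo sapiens) for antiproliferative activity, read by sulforhodamine B assay, with a stated time of 72 h (a lower number here means a stronger inhibitor, a higher number a weaker inhibitor), at 12000 nM; the nearest neighbour, compound 1 `CN(CCNCc1cn(-c2ccc(F)cc2)nn1)CCNc1ccnc2cc(Cl)ccc12`, gives 34000 nM. Compound 3 `CN(CCNCc1cn(-c2nc3ccccc3[nH]2)nn1)CCNc1ccnc2cc(Cl)ccc12` has not yet been measured, and it differs from compound 2 by 1H-benzimidazol-2-yl in place of 4-bromobenzyl on an aromatic nitrogen. For the measured compounds named here, the only step that bears on this change is a 2.8-fold lower number from compound 1 to compound 2 (0.45 log units; beyond the scatter), a modest shift seen when a group bound directly to the aromatic nitrogen was replaced by a benzyl group. Since compound 3 returns to a group bound directly to that nitrogen, a step of about a 1.7-fold higher number from compound 2 to compound 3 (0.22 log units; within the scatter) is expected. Compound 3 is therefore estimated at 20000 nM, within a range of 6000 nM to 60000 nM.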

Compound 3, half-maximal inhibitory concentration: 33000 nM
The estimate for compound 3 lay 1.7-fold (0.22 log units) below the measured number; low and high end bracket the measured number.
By their numbers in this assay, from the lowest: compound 2; then compounds 3 and 1 (each within the scatter of the next).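

In this assay, 1H-benzimidazol-2-yl on the aromatic nitrogen loses what 4-bromobenzyl had gained (a 2.8-fold higher number from compound 2 to compound 3 (0.44 log units; beyond the scatter)). It also reads level with 4-fluorophenyl (a 1.0-fold lower number from compound 1 to compound 3 (0.01 log units; within the scatter)), so the two groups bound directly to that nitrogen give matching numbers, and compound 2, with its benzyl group, stands apart. No evidence is at hand to explain this difference. Still open, on these data alone, is whether the benzyl carbon or the bromine sets compound 2 apart; a 4-fluorobenzyl group at this position would separate the two. As far as these compounds go, how an amine on the aromatic ring of that group would read also remains open.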